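The source may report more compounds than this note shows. Statements on the series, on what has been measured and on what is new or still open speak of the compounds shown alone.

Two compounds of this series have numbers in an assay on isolated protein for inhibition of Voltage-dependent N-type calcium channel subunit alpha-1B (Rattus norvegicus); on this read-out lower numbers stand for an effect already at smaller amounts and higher numbers for an effect only at larger amounts of compound. Compound 1 `NCCCOc1ccccc1C(=O)N(Cc1ccc(OCCCN=C(N)N)cc1)c1nc2ccc(Oc3ccc(O)cc3)cc2s1` gives 1780 nM. Compound 2 `NCCCOc1ccc(CNc2nc3ccc(Oc4ccccc4)cc3s2)cc1` gives 76000 nM and stands highest of the two numbers, a gap to compound 1 that lies well beyond the scatter; compound 1 differs from compound 2 at several places at once, so the two values show no single change on their own.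

Compound 3 `NC(N)=NCCCOc1ccc(CNc2nc3ccc(Oc4ccccc4)cc3s2)cc1` differs from compound 2 in one place: a group of 4 heavy atoms (1 carbon, 3 nitrogen; no ring) in place of one nitrogen atom, on a saturated chain carbon, three bonds along the chain from an oxygen on an aromatic ring. Within the data shown here, the entering group is the one that compound 1 carries at the end of its own chain, so a move toward the number of compound 1 is the expectation, though the other differences of compound 1 leave the size open. The step from compound 2 to compound 3 is expected to be a 5.1-fold lower number from compound 2 to compound 3 (0.70 log units; beyond the scatter), downward and beyond the scatter. Compound 3 is accordingly estimated at 15000 nM, within 4000 nM to 50000 nM.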

Compound 3, half-maximal effective concentration: 5800 nM
Beside the measured number, compound 3's estimate is 2.6-fold (0.41 log units) above it, and the stated range covers the measured number.
By their numbers in this assay, from the lowest: compound 1; then compound 3; then compound 2.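

In this assay, the saturated chain carbon three bonds along the chain from an oxygen on an aromatic ring proves sensitive to what it carries: replacing the amino group with the group of 4 heavy atoms gives a 13-fold lower number from compound 2 to compound 3 (1.12 log units; beyond the scatter). Among these compounds, this is the first change that can be read at a single place, whereas the gap between the two earlier compounds could not be tied to any one difference. No measurement at hand accounts for the size of this step.

Open, going by these compounds, is whether a carboxylic acid or a dimethylamine at this carbon, or a longer chain carrying the same group, would move the number in the same direction. Among the compounds shown here, also open is how much the other differences in compound 1 contribute to its value, as no single-place step connects it to compound 2 or compound 3.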